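Chloro on the anilino ring, carried into the butyl core

The source may hold more compounds than are shown below. What is called first, only, known or untested is meant among the compounds shown, and "the series" means these compounds.

Of the compounds shown here, three have been measured in a functional assay on HCT-116 cells (Homo sapiens) for antiproliferative activity, read by CCK-8 assay, with a stated time of 72 h, tested at 2 uM; a lower number here means a weaker effect, a higher number a stronger effect of the compound at the concentration tested. Compound 1 `CC(C)n1cnc2c(Nc3ccccc3)nc(NCOCc3ccc(C(=O)Nc4ccccc4N)cc3)nc21` gives 6.85%. Compound 2 `CC(C)n1cnc2c(Nc3cccc(Cl)c3)nc(NCOCc3ccc(C(=O)Nc4ccccc4N)cc3)nc21` gives 7.12%. Compound 3 `CCCCn1cnc2c(Nc3ccccc3)nc(NCOCc3ccc(C(=O)Nc4ccccc4N)cc3)nc21` gives 72.9%, the highest of the three numbers.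

The change from compound 1 to compound 2 is chloro in place of hydrogen on an aromatic carbon; it made the step of a number 0.3 percentage points higher from compound 1 to compound 2 (within the scatter). The two cores differ by butyl in place of isopropyl on an aromatic nitrogen, and that change made the step of a number 66.1 percentage points higher from compound 1 to compound 3 (beyond the scatter).

Compound 4 `CCCCn1cnc2c(Nc3cccc(Cl)c3)nc(NCOCc3ccc(C(=O)Nc4ccccc4N)cc3)nc21` is not yet measured. It differs from compound 3 by chloro in place of hydrogen on an aromatic carbon, the same change as that from compound 1 to compound 2, at the same place; among the compounds shown this change occurs twice in all. Among the compounds with values here, no other pair carries it, so the expectation rests on that single earlier pair. For compound 4 the step of a number 0.1 percentage points higher from compound 3 to compound 4 (within the scatter) is expected, because the earlier step of a number 0.3 percentage points higher from compound 1 to compound 2 (within the scatter) stayed within the scatter. Compound 4 is estimated at 73%, with a range from 55% to 88%.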

Compound 4, a percentage reported as inhibition, at one concentration (the size of the read-out at that concentration, not a potency): 58.9%
Compound 4: middle estimate off by 14.1 percentage points, on the high side; the range from low to high includes it.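

On the butyl core, chloro in place of hydrogen on the anilino ring gives a number 14 percentage points lower from compound 3 to compound 4 (beyond the scatter), so in this assay the step seen on the isopropyl core does not carry over unchanged: the same change on two cores in this assay, a number 0.3 percentage points higher (within the scatter) from compound 1 to compound 2 and a number 14 percentage points lower (beyond the scatter) from compound 3 to compound 4, 14.3 percentage points apart, beyond the scatter of two such steps

Read the other way, butyl in place of isopropyl still gives a number 51.8 percentage points higher from compound 2 to compound 4 (beyond the scatter) on the chloro-bearing pair, a large step, but its size also depends on the other group: the same change on two cores in this assay, a number 66.1 percentage points higher (beyond the scatter) from compound 1 to compound 3 and a number 51.8 percentage points higher (beyond the scatter) from compound 2 to compound 4, 14.3 percentage points apart, beyond the scatter of two such steps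

Across these four compounds the two changes therefore do not add independently, yet a single pair of cores gives no rule for other cores and does not show why the chloro step differs.

Open, as far as these compounds go, is whether the lower reading on the butyl core belongs to chloro itself or would also follow a fluoro or methoxy group at the same place on the ring. Also open, from the compounds shown here alone, is how a longer chain, such as pentyl, on the aromatic nitrogen would read, and since every value is a read-out at one concentration, whether the stronger and weaker effects seen there would hold at other concentrations remains open too.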